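The compounds below may be only part of what the source reports. "The series", "measured", "known", "first", "only" and "open" are said of these compounds alone.

Measured compounds in a functional assay on MCF7 cells (Homo sapiens) for cytotoxicity, read by MTT assay, with a stated time of 2 days; on this read-out lower numbers stand for higher toxicity in this test and higher numbers for lower toxicity in this test:
compound 1 `CC(=O)c1cc(-c2ccccc2)cc2cc(-c3ccccc3)[nH]c12` gives > 100000 nM, which is a limit of the assay.
compound 2 `CC(=O)c1cc(-c2ccc(F)cc2)cc2cc(-c3ccccc3)[nH]c12` gives > 100000 nM, which is a limit of the assay.
compound 3 `CC(=O)c1cc(/C=C/c2ccccc2)cc2cc(-c3ccccc3)[nH]c12` gives > 100000 nM, which is a limit of the assay.

Compound 3 therefore stands at the limit of this assay, not at a number, and the same holds for the two other values shown, so that it cannot be placed above or below either of them (the limit of > 100000 nM in this assay, at which 3 of the 3 values shown sit).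

Compound 4 `CC(=O)c1cc(/C=C/c2ccc(F)cc2)cc2cc(-c3ccccc3)[nH]c12`, not yet measured in this assay, differs from compound 3 by fluoro in place of hydrogen on an aromatic carbon.

The closest measured step is the same exchange on the phenyl of compound 1: a step that the two limits leave unreadable from compound 1 to compound 2. The two steps that concern the linker, a step that the two limits leave unreadable from compound 1 to compound 3 and a step that the two limits leave unreadable from compound 2 to compound 3, are likewise unreadable. With every measured value sitting at the limit, no step size in this assay can be read in either direction, and the only grounded expectation is that compound 4 stays where the series stands.

Compound 4 is therefore expected to give 100000 nM in this assay, with a range of 30000 nM to 300000 nM, which means an expected step of a number no higher from compound 3 to compound 4 (the limit leaves the size open), most likely reported again as a limit.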

Compound 4, concentration lethal to 50% of the cells: 18500 nM
Compound 4: the middle estimate sits 5.4-fold (0.73 log units) above what was measured; the measured number lies below the stated range.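

In this assay, among the compounds shown here, fluoro in place of hydrogen on the ring of the 2-phenylethenyl group, para to a large group, gives an at least 5.4-fold lower number from compound 3 to compound 4 (0.73 log units; beyond the scatter), the first readable step; the steps among the three earlier compounds cannot be read. Exchanging the 4-fluorophenyl group for 2-(4-fluorophenyl)ethenyl gives an at least 5.4-fold lower number from compound 2 to compound 4 (0.73 log units; beyond the scatter), and exchanging phenyl for 2-(4-fluorophenyl)ethenyl gives an at least 5.4-fold lower number from compound 1 to compound 4 (0.73 log units; beyond the scatter), so among these four compounds a measurable number appears only where the fluoro and the ethenyl linker occur together, while compound 2 with the fluoro alone and compound 3 with the linker alone do not reach one. These steps give only a minimum size, since each starts from a limit and not from a number: the limit of > 100000 nM in this assay, at which 3 of the 4 values shown sit.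

From the compounds shown here alone, it stays open whether this step is specific to fluoro or would also follow from chloro, methoxy or an amine at the same place on the ring. A longer chain in place of the ethenyl linker, and a carboxylic acid in place of the fluoro, would show how far this position tolerates change in this assay.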